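Capping the oxygen of compound 2 with a silicon-bearing group

The compounds below may be only part of what the source reports. "The series", "measured", "known", "first", "only" and "open" are said of these compounds alone.

In an ADME assay on PA-1 cells (Homo sapiens) for cytotoxicity, read by MTT assay, with a stated time of 72 h (a lower number here means a stronger inhibitor, a higher number a weaker inhibitor), compound 2 (`COc1ccc(C2=C(c3cc(OC)c(OC)c(OC)c3)C(=O)C(O)C2)cc1`) gives < 1 ug/mL as its reading, which is a limit and not a number. Compound 1 (`COc1ccc(C2=C(c3cc(OC)c(OC)c(OC)c3)C(=O)C(OC(C)=O)C2)cc1`) gives < 1 ug/mL as its reading, and this too is a limit. The standing of compound 2 is therefore known only as the limit of < 1 ug/mL in this assay, at which 2 of the 2 values shown sit, and cannot be placed more closely.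

Compound 3 (`COc1ccc(C2=C(c3cc(OC)c(OC)c(OC)c3)C(=O)C(O[SiH2]C(C)(C)C)C2)cc1`) differs from compound 2 by a group of 5 heavy atoms (4 carbon, 1 silicon; no ring) in place of a hydrogen atom, on an oxygen on a saturated carbon and by nothing else. Within the data shown here, one measured step bears on this change, since it puts hydrogen in place of acetyl on an oxygen on a saturated carbon, the same place. That step is a step that the two limits leave unreadable from compound 1 to compound 2 and gives no size to carry over. Among the measured compounds shown here, with a step that the two limits leave unreadable from compound 1 to compound 2 as the only guide, no step beyond the scatter is expected in this assay and no direction can be named. The expected step is a step that the limit leaves unreadable from compound 2 to compound 3 on this reading. For compound 3 the estimated value is 0.5 ug/mL with an expected range from 0.1 ug/mL to 2 ug/mL in the same assay.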

Compound 3, half-maximal inhibitory concentration: 7 ug/mL
For compound 3 the middle estimate is 14-fold (1.15 log units) below the measured one; measured number outside the range, above it.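

In this assay, the oxygen on a saturated carbon proves not to be indifferent to what caps it: a group of 5 heavy atoms (4 carbon, 1 silicon; no ring) in place of a hydrogen atom gives an at least 7.0-fold higher number from compound 2 to compound 3 (0.84 log units; beyond the scatter). The same group in place of the acetyl group gives an at least 7.0-fold higher number from compound 1 to compound 3 (0.84 log units; beyond the scatter), so both of the earlier caps at this place are separated from the silicon-bearing group by a step beyond the scatter, in the direction of a weaker reading. The step between the two earlier compounds cannot be read, and these are the first readable steps at this position, while the other two compounds remain limits and not numbers: the limit of < 1 ug/mL in this assay, at which 2 of the 3 values shown sit.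

On these data alone, the full size of both steps stays open, since each is measured from a limit, and so does any ranking of the hydroxyl and acetyl forms against each other. Also open, as far as these compounds go, is whether the weaker reading belongs to silicon itself or to the size of the group, which a plain methyl ether, a longer carbon chain or an amine at the same oxygen would begin to separate.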